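Trimming the distal phenyl of a biphenyl sulfonamide

A few compounds are considered here, and "the series" means these few. Any claim that something is new, unique, unknown or untested is made for them only; others in the source may bear on it.

Three sulfonamides sharing a bis(trifluoromethyl)phenyl core have been tested in a functional assay on BXPC-3 cells (Homo sapiens) for inhibition, read by MTT assay, with a stated time of 72 h; on this read-out lower numbers stand for stronger inhibition of growth and higher numbers for weaker inhibition of growth. Compound 1 `O=S(=O)(NCCNCc1ccc(-c2ccccc2)cc1)c1cc(C(F)(F)F)cc(C(F)(F)F)c1` gives 1600 nM. Compound 2 `O=S(=O)(NCCNCc1cccc2ccccc12)c1cc(C(F)(F)F)cc(C(F)(F)F)c1`, carrying a naphthalene in place of the biphenyl, gives 23000 nM. Compound 3 `O=S(=O)(NCCCNCc1ccc(-c2ccccc2)cc1)c1cc(C(F)(F)F)cc(C(F)(F)F)c1`, with a longer linking chain, gives 1700 nM. Among these three numbers compound 3 stands second highest: it sits within the usual scatter of compound 1, so the two cannot be told apart, whereas compound 2 lies far above it, beyond the scatter.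

The next step leads to compound 4 `COc1ccc(CNCCCNS(=O)(=O)c2cc(C(F)(F)F)cc(C(F)(F)F)c2)cc1`, which differs from compound 3 by methoxy in place of phenyl on an aromatic carbon. Among the measured compounds shown here, no measured pair shows this exact change, so its effect must be inferred. For the measured compounds named here, the only comparison touching the aryl end, compound 2 against compound 1, shows that changing this part of the molecule can cost a great deal of growth inhibition. The shrinking of the biphenyl to a methoxyphenyl is therefore expected to weaken inhibition, with the step from compound 3 to compound 4 estimated at a 2.9-fold higher number from compound 3 to compound 4 (0.47 log units; beyond the scatter). For compound 4 in this assay a value of 5000 nM is expected, within a range of 1500 nM to 20000 nM.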

Compound 4, concentration for 50% growth inhibition: 1300 nM
Estimate against measurement, compound 4: 3.8-fold (0.59 log units) above, outside the stated range (below it).
By their numbers in this assay, from the lowest: compounds 4, 1 and 3 (each within the scatter of the next); then compound 2.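

Replacing the phenyl with methoxy at this aromatic carbon, para to a large group, takes away one six-membered aromatic ring and brings in a single hydrogen-bond acceptor, with six heavy atoms leaving and two entering. In this assay this exchange gives a 1.3-fold lower number from compound 3 to compound 4 (0.12 log units; within the scatter) and so leaves growth inhibition indistinguishable, which shows that on the chain of compound 3 the outer phenyl is not required to hold the level of inhibition seen with the biphenyl. Nothing measured here accounts for this tolerance.

The compounds shown leave open whether a hydroxy group, a chlorine atom or a plain hydrogen on this carbon would give a similar number. They also leave open whether methoxy would be tolerated equally on the chain of compound 1.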